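The source may report more compounds than this note shows. Statements on the series, on what has been measured and on what is new or still open speak of the compounds shown alone.

Measured compounds in this series:
compound 1, `N#CNC(=N)NCCCCCn1nc(-c2ccccc2)ccc1=O`, 31% in a functional assay on the whole organism with Rattus norvegicus as the target, at a dose of 100 mg/kg; a higher number here means more inhibition at the dose given (going by the name of the read-out), a lower number less inhibition
compound 2, `CC/N=C(\S)NCCCCCCn1nc(-c2ccccc2)ccc1=O`, -5.6% in this assay
compound 3, `O=c1ccc(-c2ccccc2)nn1CCCCNC(=S)Nc1ccccc1`, 38.4% in this assay

Compound 3 gives the highest number of the three, but its gap to compound 1 lies within the scatter, so the two cannot be ordered; only compound 2 stands clearly apart from it, beyond the scatter.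

Compound 4, `C/N=C(\S)NCCCCn1nc(-c2ccccc2)ccc1=O`, is not yet measured. The change from compound 3 is a group of 4 heavy atoms (2 carbon, 1 nitrogen, 1 sulfur; no ring) in place of a group of 9 heavy atoms (7 carbon, 1 nitrogen, 1 sulfur; one six-membered aromatic ring of carbon only), on an amine nitrogen.

For the measured compounds named here, the one measured step that bears on this is a number 36.6 percentage points lower from compound 1 to compound 2 (beyond the scatter). That step sits at a different place, on a chain carbon rather than on an amine nitrogen, but the group that enters in compound 4 resembles the group that enters in compound 2, and compound 2 gives -5.6%, the lowest number of the set. A loss of inhibition is therefore expected, though a smaller one is plausible since the change here is a cut of the group rather than a swap of its kind.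

Compound 4 is expected to give about 12%, with a plausible range from -10% to 32%, an estimated step of a number 26.4 percentage points lower from compound 3 to compound 4 (beyond the scatter).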

Compound 4, a percentage reported as inhibition, in the whole organism at one dose (the size of the read-out at that dose, not a potency): 87.1%
Beside the measured number, compound 4's estimate is 75.1 percentage points below it; measured number above the stated range.
By their numbers in this assay, from the lowest: compound 2; then compounds 1 and 3 (each within the scatter of the next); then compound 4.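

In this assay, a number 48.7 percentage points higher from compound 3 to compound 4 (beyond the scatter) shows that the six-membered aromatic ring of compound 3 is not needed for inhibition at the amine nitrogen, and that the group of 4 heavy atoms without a ring gives far more. The further steps, a number 92.7 percentage points higher from compound 2 to compound 4 (beyond the scatter) and a number 56.1 percentage points higher from compound 1 to compound 4 (beyond the scatter), place compound 4 clear of every other compound, so the low number of compound 2 does not carry over to all groups of this type. Nothing at hand explains these steps.

Those two further steps alter the chain and its end group together, so the share of each remains unresolved. Also open, as far as these compounds go, is whether an ethyl or a cyclohexyl group on the same amine nitrogen would keep this level of inhibition on the shorter chain.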